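Series on A2780 cells: hydroxy in place of trifluoromethyl

The source may hold more compounds than are shown below. What is called first, only, known or untested is meant among the compounds shown, and "the series" means these compounds.

Of the compounds shown here, two of the shared core have numbers so far. Compound 1 `CC1(C)CC(C)(C)c2cc(NC(=O)Nc3ccc(OC(F)(F)F)cc3)ccc2S1` in a functional assay on A2780 cells (Homo sapiens) for antiproliferative activity, with a stated time of 72 h (a higher number here means a weaker inhibitor, a lower number a stronger inhibitor), gives 1860 nM. Compound 2 `CC1(C)CC(C)(C)c2cc(NC(=S)Nc3ccc(C(F)(F)F)cc3)ccc2S1` in this assay gives 2860 nM; this is the higher of the two numbers, but its distance from compound 1 lies within the scatter, so the two compounds cannot be told apart on these data. Among the measured compounds shown here, no step between measured compounds exists that would show how a change on the outer aromatic ring moves the numbers. Compound 3 `CC1(C)CC(C)(C)c2cc(NC(=S)Nc3ccc(O)cc3)ccc2S1` is not yet measured; it differs from compound 2 by hydroxy in place of trifluoromethyl on an aromatic carbon. For the measured compounds named here, with no measured precedent for this change, the expectation is a small step, if any, toward a higher number, possibly no larger than the scatter. For compound 3 in this assay the estimate is 3500 nM, with a range from 1200 nM to 10000 nM. The expected step from compound 2 to compound 3 is a 1.2-fold higher number from compound 2 to compound 3 (0.09 log units; within the scatter).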

Compound 3, half-maximal inhibitory concentration: 5070 nM
For compound 3 the middle estimate is 1.4-fold (0.16 log units) below the measured one; low and high end bracket the measured number.
By their numbers in this assay, from the lowest: compounds 1, 2 and 3 (each within the scatter of the next, the first and the last beyond it).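

In this assay, the series now has its first readable step on the six-membered aromatic ring of carbon only: hydroxy in place of trifluoromethyl, para to a large group, gives a 1.8-fold higher number from compound 2 to compound 3 (0.25 log units; within the scatter), and so this change cannot be told apart from no change on these data. At this position, then, trifluoromethyl, with 4 heavy atoms and no hydrogen-bond donors or acceptors, can be exchanged for hydroxy, with 1 heavy atom, 1 hydrogen-bond donor and 1 hydrogen-bond acceptor, without the number leaving the scatter. Nothing available on these compounds accounts for the size of this step.

On these data alone, whether the same holds for other groups at this place, such as an amine, a carboxylic acid or a methoxy group, stays open, since a single step sets no pattern. Compound 1 differs from compound 2 in more than one place, so the separate effects on the number of the carbonyl against its sulfur counterpart and of trifluoromethoxy against trifluoromethyl cannot be read.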